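This account rests on a few compounds, and the source may have more. Where it says the series, first, only, none or still open, it means among the compounds named here.

Working notes on a small series of indoles bearing a para-hydroxyphenyl group, all tested in a functional assay on MSTO-211H cells (Homo sapiens) for inhibition, read by trypan blue exclusion, with a stated time of 72 h; on this read-out higher numbers stand for weaker inhibition of growth and lower numbers for stronger inhibition of growth.

Compound 1 `CCCn1c(-c2ccc(O)cc2)c(C)c2ccccc21` is the parent; in this assay compound 1 gives 7100 nM. Compound 2 `CCCn1c(-c2ccc(O)cc2)c(C)c2cc(O)ccc21` carries the change hydroxy in place of hydrogen on an aromatic carbon and gives 2900 nM in this assay; the step of a 2.4-fold lower number from compound 1 to compound 2 (0.39 log units; beyond the scatter) is modest but beyond the scatter. Compound 3 `Cc1c(-c2ccc(O)cc2)n(CCCCOc2ccccc2)c2ccccc12` differs from compound 1 by phenoxymethyl in place of hydrogen on a saturated chain carbon, three bonds along the chain from an aromatic nitrogen; in this assay compound 3 gives 3300 nM, and the step of a 2.2-fold lower number from compound 1 to compound 3 (0.33 log units; beyond the scatter) is of similar size. The values of compound 2 and compound 3 lie within the scatter of each other, so no order between them is claimed.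

Compound 4 `Cc1c(-c2ccc(O)cc2)n(CCCCOc2ccccc2)c2ccc(O)cc12` is not yet measured. It differs from compound 3 by hydroxy in place of hydrogen on an aromatic carbon, the same change as from compound 1 to compound 2, made on the same place in words, but on the core of compound 3 rather than that of compound 1; the two cores differ by phenoxymethyl in place of hydrogen on a saturated chain carbon, three bonds along the chain from an aromatic nitrogen. The step expected for compound 4 is a 2.4-fold lower number from compound 3 to compound 4 (0.37 log units; beyond the scatter) in this assay, beside the earlier 2.4-fold lower number from compound 1 to compound 2 (0.39 log units; beyond the scatter), resting on that single measured instance. Compound 4 is estimated at 1400 nM in this assay, between 600 nM and 3300 nM.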

Compound 4, concentration for 50% growth inhibition: 2900 nM
Compound 4: middle estimate off by 2.1-fold (0.32 log units), on the low side; measured number inside the range.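

In this assay, hydroxy in place of hydrogen on an aromatic carbon gives a 1.1-fold lower number from compound 3 to compound 4 (0.06 log units; within the scatter), so on this second core the change yields no step beyond the scatter, yet the two steps cannot be told apart: the same change on two cores in this assay, a 2.4-fold lower number (0.39 log units; beyond the scatter) from compound 1 to compound 2 and a 1.1-fold lower number (0.06 log units; within the scatter) from compound 3 to compound 4, 2.2-fold (0.33 log units) apart, within the scatter of two such steps The phenoxymethyl change, read on the core that already carries the added hydroxy, gives no change at the digits printed from compound 2 to compound 4 (within the scatter), and again the two steps cannot be told apart: the same change on two cores in this assay, a 2.2-fold lower number (0.33 log units; beyond the scatter) from compound 1 to compound 3 and no change at the digits printed (within the scatter) from compound 2 to compound 4, 2.2-fold (0.33 log units) apart, within the scatter of two such steps These four compounds therefore show neither that each change carries over at full size nor that its step is lost on the other core; they rest on a single pair of steps for each change, and the differences between those steps stay within the scatter.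

The compounds shown leave open what an amine or a carboxylic acid in place of the phenoxymethyl group would do in this assay. Also open, as far as these compounds go, are the effects of a longer chain and of a methoxy group in place of the added hydroxy.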